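Compound 3 to compound 4: swapping the aromatic ring

The source may hold more compounds than are shown below. What is called first, only, known or untested is meant among the compounds shown, and "the series" means these compounds.

In a functional assay on MDA-MB-436 cells (Homo sapiens) for antiproliferative activity, read by MTT assay, with a stated time of 48 h (on this read-out lower numbers stand for stronger inhibition and higher numbers for weaker inhibition), compound 1 `CCS(=O)(=O)N1CCN(c2ncnc3sc(-c4ccc(N5CCN(C)CC5)cc4)cc23)CC1` gives 10600 nM and compound 2 `CN1CCN(c2ccc(-c3cc4c(N5CCN(S(=O)(=O)C6CC6)CC5)ncnc4s3)cc2)CC1` gives 10600 nM. Exchanging ethyl for cyclopropyl on the sulfonyl sulfur shows no change at the digits printed from compound 1 to compound 2 (within the scatter). Compound 3 `COc1ccc(NC(=O)N2CCN(c3ncnc4sc(-c5ccc(N6CCN(C)CC6)cc5)cc34)CC2)cc1` stands highest of the three at 30100 nM. Its (4-methoxyphenyl)carbamoyl group in place of ethylsulfonyl gives a 2.8-fold higher number from compound 1 to compound 3 (0.45 log units; beyond the scatter), a modest step. Compound 4 `CN1CCN(c2ccc(-c3cc4c(N5CCN(C(=O)Nc6cccc(F)c6)CC5)ncnc4s3)cc2)CC1` has 3-fluorophenyl in place of 4-methoxyphenyl on an amide-type nitrogen. Among the compounds with values here, no measured step changes this ring alone, so the guides are indirect. Even the larger group exchange gave only a 2.8-fold higher number from compound 2 to compound 3 (0.45 log units; beyond the scatter), so little movement is expected in this assay. The expected result is a 1.3-fold lower number from compound 3 to compound 4 (0.10 log units; within the scatter), which would be no step beyond the scatter. For compound 4 the estimated value is 24000 nM, with an expected range of 10000 nM to 55000 nM.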

Compound 4, half-maximal inhibitory concentration: 18300 nM
Compound 4: the middle estimate sits 1.3-fold (0.12 log units) above what was measured, and the stated range covers the measured number.
By their numbers in this assay, from the lowest: compounds 1, 2, 4 and 3 (each within the scatter of the next, the first and the last beyond it).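

In this assay the direct ring swap gives a 1.6-fold lower number from compound 3 to compound 4 (0.22 log units; within the scatter) and so leaves the number at this position within the scatter. The carbamoyl link also no longer separates clearly from the sulfonyl groups: a 1.7-fold higher number from compound 2 to compound 4 (0.24 log units; within the scatter) and a 1.7-fold higher number from compound 1 to compound 4 (0.24 log units; within the scatter) both stay within the scatter, whereas compound 3 stood beyond it. No measurement shown here offers an explanation for these differences.

Still open, going by these compounds, is whether a phenyl ring carrying an amine or a carboxylic acid, or a longer chain in place of the ring, would move the number beyond the scatter.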